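Swapping the amide substituent in a series inactive on prostate cells

The source may report more compounds than this note shows. Statements on the series, on what has been measured and on what is new or still open speak of the compounds shown alone.

Measured compounds in a functional assay on PC-3 cells (Homo sapiens) for cytotoxicity, read by MTT assay, with a stated time of 72 h; on this read-out lower numbers stand for stronger inhibition and higher numbers for weaker inhibition:
compound 1 `COCOc1cc(/C=C/C(=O)OCC(=O)NCc2ccco2)ccc1OCc1ccccc1`: > 200000 nM
compound 2 `CCOc1ccc(COc2c(OC)cc(/C=C/C(=O)OCC(=O)Nc3ccccc3)cc2OC)cc1`: > 200000 nM
compound 3 `COc1ccc(NC(=O)COC(=O)/C=C/c2cc(OC)c(OCc3ccc(Cl)c(Cl)c3)c(OC)c2)cc1`: > 200000 nM

Compound 1 stands at the limit of this assay, not at a measured number. Compound 2 likewise reports only a limit. Compound 3 also reports only a limit. Taken together, the whole measured set sits at one point: the limit of > 200000 nM in this assay, at which 3 of the 3 values shown sit. Nothing in these three values separates one compound from another, so no ordering among them can be drawn.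

Compound 4 `COCOc1cc(/C=C/C(=O)OCC(=O)NN2CCOCC2)ccc1OCc1ccccc1` has not yet been measured. Set against compound 1 it shows (morpholin-4-yl in place of (furan-2-yl)methyl on an amide-type nitrogen).

Among the measured compounds shown here, no pair of measured compounds differs in a single place, so no step size is on record for this series. Because every measured value sits at the limit of > 200000 nM in this assay, at which 3 of the 3 values shown sit, a change confined to the substituent on the amide-type nitrogen is expected to leave the read-out where it is, and the step is estimated as a number no higher from compound 1 to compound 4 (the limit leaves the size open), none beyond the scatter. Compound 4 is therefore expected to give 200000 nM in this assay, within 60000 nM to 600000 nM, and most likely to be reported once more only as a limit rather than a number.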

Compound 4, half-maximal inhibitory concentration: > 200000 nM
Compound 4: only a limit was reported (the forecaster's own chance of this, stated with the estimate: 85%); the middle value sits exactly at the limit.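

In this assay compound 4 gives > 200000 nM as a limit of the assay and not a number. Compound 1 also gives > 200000 nM as a limit. Among the compounds shown here, no step from compound 1 to compound 4 can therefore be read. The compounds shown leave open whether any substituent on the amide-type nitrogen would give a measured number in this assay at all.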